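The source may report more compounds than this note shows. Statements on the series, on what has been measured and on what is new or still open speak of the compounds shown alone.

Measured in a physicochemical assay for acid dissociation:
compound 1 `Cc1cc(C)cc(Cc2ccc3c(NCCCNCc4ccco4)ccnc3c2)c1` gives 9.47
compound 2 `CN(C)c1cccc(Oc2ccc3c(NCCCNCc4ccco4)ccnc3c2)c1` gives 9.28

Compound 2 stands at the lower of the two numbers, and the step of a number 0.19 log units lower from compound 1 to compound 2 (within the scatter) places it within the scatter of compound 1. Compound 3 `N#Cc1ccc(Cc2ccc3c(NCCCNCc4ccco4)ccnc3c2)cc1` is not yet measured. It differs from compound 2 by 4-cyanobenzyl in place of 3-(dimethylamino)phenoxy on an aromatic carbon. Within the data shown here, the only step that bears on this change is the one from compound 1 to compound 2, which also exchanged the group on the same aromatic carbon and stayed within the scatter. For compound 3 a step of a number 0.07 log units higher from compound 2 to compound 3 (within the scatter) is therefore expected, with no change beyond the scatter. Compound 3 is estimated at 9.35, between 9 and 9.7.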

Compound 3, acid dissociation constant: 9.47
The estimate for compound 3 lay 0.12 log units below the measured number; measured number inside the range.
By their numbers in this assay, from the lowest: compounds 2, 1 and 3 (each within the scatter of the next).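

In this assay the entry of 4-cyanobenzyl gives a number 0.19 log units higher from compound 2 to compound 3 (within the scatter) and no change at the digits printed from compound 1 to compound 3 (within the scatter) at this aromatic carbon. A nitrile-bearing group therefore joins 3,5-dimethylbenzyl and 3-(dimethylamino)phenoxy within the scatter, so the three compounds show no separation at this position. No supporting measurement is available to account for this result.

Still open, on these data alone, is whether a group carrying an amine or a carboxylic acid at this aromatic carbon would also stay within the scatter. Also open, as far as these compounds go, is whether a change elsewhere on the shared core would shift the number.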